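Pyridin-2-yl in place of 2-hydroxyphenyl: working notes

A few compounds are considered here, and "the series" means these few. Any claim that something is new, unique, unknown or untested is made for them only; others in the source may bear on it.

In a functional assay on HepG2 cells (Homo sapiens) for antiproliferative activity, read by MTT assay, with a stated time of 48 h (a lower number here means a stronger inhibitor, a higher number a weaker inhibitor), compound 1 (`CC(=O)N1N=C(c2ccc3ccccc3c2)OC1c1cccc(F)c1`) gives 1.86 ug/mL and compound 2 (`CC(=O)N1N=C(c2ccc3ccccc3c2)OC1c1ccccc1O`) gives 1.84 ug/mL. Among the compounds with values here, compound 2 therefore stands level with compound 1, the only other measured member of the series, and the gap between them lies within the scatter.

Compound 3 (`CC(=O)N1N=C(c2ccc3ccccc3c2)OC1c1ccccn1`) keeps the shared core and carries pyridin-2-yl in place of 2-hydroxyphenyl on a saturated ring carbon, next to the ring nitrogen and next to the ring oxygen: pyridin-2-yl in place of 2-hydroxyphenyl on a saturated ring carbon.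

Within the data shown here, one measured step bears on this change. It concerns the same ring carbon, where 2-hydroxyphenyl replaced 3-fluorophenyl, and it amounts to a 1.0-fold lower number from compound 1 to compound 2 (0.00 log units; within the scatter). Among the measured compounds shown here, no measured compound carries pyridin-2-yl, so this evidence is thin and the range must stay wide. Given that single step of a 1.0-fold lower number from compound 1 to compound 2 (0.00 log units; within the scatter), no change beyond the scatter is expected in this assay. The estimated step is a 1.1-fold higher number from compound 2 to compound 3 (0.04 log units; within the scatter). Compound 3 is expected at about 2 ug/mL, with an estimated range of 0.9 ug/mL to 5 ug/mL.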

Compound 3, half-maximal inhibitory concentration: 5.26 ug/mL
Estimate against measurement, compound 3: 2.6-fold (0.42 log units) below; measured number above the stated range.
By their numbers in this assay, from the lowest: compounds 2 and 1 (each within the scatter of the next); then compound 3.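

In this assay this saturated ring carbon turns out not to be indifferent to its aromatic group, since pyridin-2-yl gives a 2.9-fold higher number from compound 2 to compound 3 (0.46 log units; beyond the scatter) and likewise a 2.8-fold higher number from compound 1 to compound 3 (0.45 log units; beyond the scatter) where the earlier pair showed no separation. Compound 1, with 3-fluorophenyl and no hydroxyl, stands level with compound 2, so the loss of the hydroxyl does not by itself track the weaker result; among these three compounds, the one feature found only in compound 3 is the ring nitrogen of pyridin-2-yl, while compounds 1 and 2 both carry a six-membered aromatic ring of carbon only. Nothing measured here explains why this replacement weakens the result.

Still open, from the compounds shown here alone, is whether the place of the ring nitrogen matters, which pyridin-3-yl or pyridin-4-yl on this carbon would address, and whether an unsubstituted phenyl would stand level with compounds 1 and 2. Going by these compounds, all three compounds also share the acetyl group, so it remains unknown whether the step would hold with a propanoyl group there instead.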